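A few compounds are considered here, and "the series" means these few. Any claim that something is new, unique, unknown or untested is made for them only; others in the source may bear on it.

Among the measured compounds shown here, compound 1 `Brc1cn2ccnc2c(-c2ccc3ncn(C4CCCCC4)c3c2)n1` gives 5.16% in a functional assay on BT-549 cells (Homo sapiens) for inhibition, read by sulforhodamine B assay, with a stated time of 48 h, tested at 10 uM (on this read-out higher numbers stand for more inhibition at the one concentration tested (going by the name of the read-out) and lower numbers for less inhibition), the lower of the two numbers measured so far. Compound 2 `Brc1ccc(-c2cn3ccnc3c(-c3ccc4ncn(C5CCCCC5)c4c3)n2)cc1` gives 35.1% in this assay. For the measured compounds named here, that step, a number 29.9 percentage points higher from compound 1 to compound 2 (beyond the scatter), is the one measured step that bears on the present case: it too puts an aromatic ring in place of the bromo. Compound 3 `Fc1ccccc1-c1cn2ccnc2c(-c2ccc3ncn(C4CCCCC4)c3c2)n1` differs from compound 1 by 2-fluorophenyl in place of bromo on an aromatic carbon. A step of similar direction and roughly similar size is therefore expected, a number 22.8 percentage points higher from compound 1 to compound 3 (beyond the scatter). Compound 3 is estimated at 28%, with a range from 10% to 50%.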

Compound 3, a percentage reported as inhibition, at one concentration (the size of the read-out at that concentration, not a potency): 4.08%
Estimate against measurement, compound 3: 23.9 percentage points above, and the stated range ends above it.
By their numbers in this assay, from the lowest: compounds 3 and 1 (each within the scatter of the next); then compound 2.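

Putting an aromatic ring on this carbon does not by itself raise the number in this assay: a number 1.1 percentage points lower from compound 1 to compound 3 (within the scatter), so 2-fluorophenyl and bromo cannot be told apart here. The choice of ring does count, with a number 31 percentage points lower from compound 2 to compound 3 (beyond the scatter). Nothing available explains this gap between the two rings.

Going by these compounds, these two rings differ in both their halogen and its place, so which of the two matters remains open. Also open, on these data alone, is what a plain phenyl ring, or a phenyl ring carrying an amine, would give.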